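Swapping a Chloropyridine for an Acetamidophenyl

The compounds below may be only part of what the source reports. "The series", "measured", "known", "first", "only" and "open" are said of these compounds alone.

Of the compounds shown here, three built on one shared core have been tested in an assay on CHO-K1 cells for displacement of a labelled ligand from adenosine receptor A1 (Homo sapiens), read by scintillation counting, with a stated time of 60 min; a lower number here means a stronger inhibitor, a higher number a weaker inhibitor. Compound 2 `Nc1nc(N/N=C/c2cccnc2Cl)nc2c1ncn2[C@@H]1O[C@H](CO)[C@@H](O)[C@H]1O` gives 4.6 nM, the lowest of the two plain numbers. Compound 1 `CC(/C=N/Nc1nc(N)c2ncn([C@@H]3O[C@H](CO)[C@@H](O)[C@H]3O)c2n1)Cc1ccc(C(C)C)cc1`, which carries a longer chain ending in an isopropyl-substituted ring, gives 9500 nM in this assay, a far higher number than compound 2. Compound 3 `Nc1nc(N/N=C/c2ccc(OCc3ccccc3)c(OCc3ccccc3)c2)nc2c1ncn2[C@@H]1O[C@H](CO)[C@@H](O)[C@H]1O` reaches only the limit of this assay, > 10000 nM, so no number is known for it; (the limit of > 10000 nM in this assay, at which 1 of the 3 values shown sits).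

Compound 4 `CC(=O)Nc1ccc(/C=N/Nc2nc(N)c3ncn([C@@H]4O[C@H](CO)[C@@H](O)[C@H]4O)c3n2)cc1` has not yet been measured. It differs from compound 2 in one place: 4-acetamidophenyl in place of 2-chloropyridin-3-yl on a carbon with a double bond to nitrogen. Among the compounds with values here, no measured pair differs in just one place, so the size of this step can only be guessed from the spread of the three results, where only compound 2 sits low.

Compound 4 is expected to give a higher number than compound 2, a step estimated as a 43-fold higher number from compound 2 to compound 4 (1.64 log units; beyond the scatter). The estimate for compound 4 in this assay is 200 nM, within a range from 20 nM to 3000 nM.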

Compound 4, inhibition constant: > 10000 nM
Compound 4 ended at the assay's limit; the forecaster's own chance of this, stated with the estimate: 15%; middle value at least 50-fold (1.69 log units) away from the limit.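

In this assay, within the data shown here, this is the only step so far that changes a single place, and swapping 2-chloropyridin-3-yl for 4-acetamidophenyl gives an at least 2100-fold higher number from compound 2 to compound 4 (3.33 log units; beyond the scatter). The result for compound 4, > 10000 nM, is a limit of the assay and not a number. With the shared core unchanged, this one swap on the carbon with a double bond to nitrogen is enough to lose the low number of compound 2, and the set now holds a second result at the limit: the limit of > 10000 nM in this assay, at which 2 of the 4 values shown sit.

The swap changes the ring and its substituent together, so these compounds leave open whether the chlorine, the ring nitrogen or the acetamido group matters most. How a plain phenyl or a 4-aminophenyl group would behave at this place cannot be read from the compounds shown.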